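This account rests on a few compounds, and the source may have more. Where it says the series, first, only, none or still open, it means among the compounds named here.

Measured compounds:
- compound 1: `CC(C)/C(=N\Nc1nc2ccccc2o1)c1ccccn1` — 21 nM
- compound 2: `C/C(=N\Nc1nc2ccccc2o1)c1ccc2ccccc2n1` — 7040 nM
- compound 3: `C(=N/Nc1nc2ccccc2o1)\c1ccccn1` — 40 nM

Of the compounds shown here, three built on a shared core have been tested in a functional assay on CCRF-CEM cells (Homo sapiens) for antiproliferative activity, read by MTT assay; on this read-out lower numbers stand for stronger inhibition and higher numbers for weaker inhibition. Compound 1 (`CC(C)/C(=N\Nc1nc2ccccc2o1)c1ccccn1`) gives 21 nM in this assay, the lowest of the three numbers. Compound 3 (`C(=N/Nc1nc2ccccc2o1)\c1ccccn1`) gives 40 nM, and the values of compound 1 and compound 3 lie within the scatter of each other. Compound 2 (`C/C(=N\Nc1nc2ccccc2o1)c1ccc2ccccc2n1`) gives 7040 nM, a number far beyond the scatter from compound 1; it differs from compound 1 in more than one place, so only the two values can be set side by side.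

Compound 4 (`CC(C)(C)/C(=N\Nc1nc2ccccc2o1)c1ccccn1`) has not yet been measured. The change from compound 1 to compound 4 is methyl in place of hydrogen on a saturated chain carbon bound to a carbon with a double bond to nitrogen and two saturated chain carbons. Cut one bond further out, the same change reads isopropyl to tert-butyl. Within the data shown here, no single-change step among the measured compounds shows how adding a methyl at this place acts. Since compound 1 and compound 3 sit within the scatter of each other, a small step in this assay is expected, at most a mild move toward a higher number, estimated as a 2.4-fold higher number from compound 1 to compound 4 (0.38 log units; beyond the scatter). Compound 4 is expected to give 50 nM, with a range from 12 nM to 250 nM.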

Compound 4, half-maximal inhibitory concentration: > 10000 nM
Compound 4: only a limit was reported; the forecaster's own chance of this, stated with the estimate: 3%; middle value at least 200-fold (2.30 log units) from the limit.
By their numbers in this assay, from the lowest: compounds 1 and 3 (each within the scatter of the next); then compound 2. At a limit, above all of these: compound 4.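

Among these compounds, at this saturated chain carbon, the change from isopropyl to tert-butyl gives the first single-change step in this assay, and it is large: an at least 470-fold higher number from compound 1 to compound 4 (2.67 log units; beyond the scatter) for one methyl in place of hydrogen. Among the compounds shown here, compound 4 gives > 10000 nM in this assay, which is a limit of the assay and not a number: the limit of > 10000 nM in this assay, at which 1 of the 4 values shown sits. The earlier compounds offered no single-change step at all, so this is the first sign that one methyl at this place can move the read-out strongly toward weaker inhibition.

The compounds shown leave open how other groups at this place would read, such as a cyclopropyl ring, a longer chain like n-butyl, or an amine, and so whether so large a step belongs to tert-butyl alone or to a wider set of groups. For the compounds shown here, they also give no way of telling what lies behind the step, as they hold only this one comparison at this position, in this one assay on one cell line.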